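Swapping a benzyl group on two related cores

The compounds below may be only part of what the source reports. "The series", "measured", "known", "first", "only" and "open" are said of these compounds alone.

Compound 1 `Cc1ccc(COc2ccc(-c3nn(CCC#N)c(=S)o3)cc2)cc1` and compound 2 `N#CCCn1nc(-c2ccc(OCc3cccc(Cl)c3)cc2)oc1=S` share one core and differ only in one group. In an assay for inhibition of Amine oxidase [flavin-containing] A (Rattus norvegicus) (on this read-out higher numbers stand for weaker inhibition and lower numbers for stronger inhibition), compound 1 gives 10000 nM, and compound 2 gives 11000 nM. The change between them is 3-chlorophenyl in place of 4-methylphenyl on a saturated chain carbon bound to an oxygen on an aromatic ring and it made a 1.1-fold higher number from compound 1 to compound 2 (0.04 log units; within the scatter), so the two numbers cannot be told apart.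

Compound 3 `Cc1ccc(COc2ccc(C3=NN(CCC#N)C(=O)CO3)cc2)cc1` carries the same 4-methylbenzyl part as compound 1 but sits on a different core; how the two cores differ is not broken down here. In this assay compound 3 gives 250000 nM, the highest number of the three, well beyond the scatter from both compound 1 and compound 2.

Compound 4 `N#CCCN1N=C(c2ccc(OCc3cccc(Cl)c3)cc2)OCC1=O` is to compound 3 what compound 2 is to compound 1: the change is 3-chlorophenyl in place of 4-methylphenyl on a saturated chain carbon bound to an oxygen on an aromatic ring, on the same place in the same words, so it is the same change made a second time, now on the core of compound 3. Because the earlier step was a 1.1-fold higher number from compound 1 to compound 2 (0.04 log units; within the scatter), the expected step here is a 1.1-fold higher number from compound 3 to compound 4 (0.03 log units; within the scatter), resting on that single earlier pair only. In this assay compound 4 is therefore expected to give about 270000 nM, estimated to fall between 120000 nM and 600000 nM, since a value this high on compound 3 may also be reported only as a limit.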

Compound 4, half-maximal inhibitory concentration: 13000 nM
Estimate against measurement, compound 4: 21-fold (1.32 log units) above, outside the stated range (below it).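

In this assay, the same swap of 4-methylbenzyl to 3-chlorobenzyl that changed nothing readable on the core of compound 1 gave a 19-fold lower number from compound 3 to compound 4 (1.28 log units; beyond the scatter). Set side by side, the two results do not agree: the same change on two cores in this assay, a 1.1-fold higher number (0.04 log units; within the scatter) from compound 1 to compound 2 and a 19-fold lower number (1.28 log units; beyond the scatter) from compound 3 to compound 4, 21-fold (1.33 log units) apart, beyond the scatter of two such steps. Going by these compounds alone, this shows that, for these two pairs, the size of the step on one core did not predict the size of the step on the other, so the effect of this change cannot simply be carried across cores; it does not show which feature of the cores is responsible, and with only one pair on each core it cannot show how a further core would behave.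

The compounds shown carry only 4-methylbenzyl and 3-chlorobenzyl, so it stays open whether a plain benzyl group, or a benzyl group carrying a methoxy group, would show the same gap between the two cores, and whether the chlorine or the loss of the methyl matters more. The nitrile-bearing chain is also the same throughout, which leaves open what a longer chain or an amine in its place would do on either core.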